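Acyl change on the shared core: aryl to ethyl

The source may hold more compounds than are shown below. What is called first, only, known or untested is meant among the compounds shown, and "the series" means these compounds.

The series shares the core of compound 1 `O=C(Nc1cc(C(F)(F)F)cc(C(F)(F)F)c1)C1CCc2ccccc2N1C(=O)c1ccccc1Cl` and varies both the group on the carbonyl at the amide-type nitrogen in a ring and the amide end. In a functional assay on MDA-MB-231 cells (Homo sapiens) for cytotoxicity, read by sulforhodamine B assay, with a stated time of 72 h (a lower number here means a stronger inhibitor of growth, a higher number a weaker inhibitor of growth), compound 1 gives 5250 nM, the second highest of the three numbers measured. Compound 3 `O=C(Nc1ccccc1C(F)(F)F)C1CCc2ccccc2N1C(=O)c1ccc(Cl)cc1` gives 533 nM, a lower number beyond the scatter, while compound 2 `CCCCCCCCC(=O)N1c2ccccc2CCC1C(=O)Nc1ccccc1O` gives 54300 nM, a higher number beyond the scatter; compound 2 carries a chain rather than a ring on that carbonyl. Compound 4 `CCC(=O)N1c2ccccc2CCC1C(=O)Nc1cc(C(F)(F)F)cc(C(F)(F)F)c1` is not yet measured. Against compound 1 the change is ethyl in place of 2-chlorophenyl on a carbonyl carbon. Among the compounds with values here, no measured pair isolates this change, since compound 2 differs from compound 3 at more than one place. A higher number is expected, with the step from compound 1 to compound 4 estimated at a 2.3-fold higher number from compound 1 to compound 4 (0.36 log units; beyond the scatter). Compound 4 is estimated at 12000 nM, expected within 4000 nM to 40000 nM.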

Compound 4, concentration for 50% growth inhibition: 7280 nM
Beside the measured number, compound 4's estimate is 1.6-fold (0.22 log units) above it; measured number inside the range.
By their numbers in this assay, from the lowest: compound 3; then compounds 1 and 4 (each within the scatter of the next); then compound 2.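

In this assay, ethyl in place of 2-chlorophenyl on a carbonyl carbon gives a 1.4-fold higher number from compound 1 to compound 4 (0.14 log units; within the scatter). Within the data shown here, this is the first single-place reading at this position: in this one pair, the aromatic ring and its chlorine leave with no change beyond the scatter, which the earlier compounds, differing in more than one place, could not show. No measurement at hand bears on why this pair reads alike. Open, going by these compounds, is whether an amine or a carboxylic acid carried on this carbonyl would read the same, and whether the swap from 2-chlorophenyl to ethyl holds with the amide end of compound 3.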